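Inverting One Ring Stereocentre: Compound 2 to Compound 4

The compounds below may be only part of what the source reports. "The series", "measured", "known", "first", "only" and "open" are said of these compounds alone.

Among the compounds with values here, compound 2 `COc1ccc(C2(C(=O)O)CCCCC2)cc1[C@H]1O[C@@H](C)[C@@H](O)[C@H](O)[C@@H]1O` stands second highest among the three numbers known so far in an assay on isolated protein for binding affinity to L-selectin (Homo sapiens), read by ELISA; a lower number here means a stronger inhibitor, a higher number a weaker inhibitor; compound 2 gives 106000 nM. Its nearest neighbour is compound 1 `COc1ccc(CCCC(=O)O)cc1C1OC(C)C(O)C(O)C1O`, which in this assay gives 170000 nM, a gap within the usual scatter, so no order between these two can be read. Furthest away is compound 3 `COc1ccc(C2(C(=O)O)CCCCC2)cc1C1OCC(O)C(O)C1O`, which in this assay gives 11000 nM, a gap beyond the scatter. Within the data shown here, no pair among the three differs in only one place, so no single step has yet been measured.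

Compound 4 `COc1ccc(C2(C(=O)O)CCCCC2)cc1[C@H]1O[C@@H](C)[C@H](O)[C@H](O)[C@@H]1O` is now set against compound 2: the two compounds have the same atoms and bonds and differ only in configuration as drawn: 1 of 5 stereo elements differ; a stereocentre at a saturated ring carbon is drawn S in compound 2 and R in compound 4. Among the measured compounds shown here, every atom and bond stays in place, and the known compounds offer no measured step of this kind to lean on. Without such a step, no direction can be argued from the data, and a change within the scatter is as plausible as one beyond it in either sense. Compound 4 is therefore expected near 100000 nM, with a broad range from 30000 nM to 350000 nM. The expected step is a 1.1-fold lower number from compound 2 to compound 4 (0.03 log units; within the scatter), centred within the scatter but with wide uncertainty on both sides.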

Compound 4, half-maximal inhibitory concentration: 35000 nM
Compound 4: middle estimate off by 2.9-fold (0.46 log units), on the high side, and the stated range covers the measured number.
By their numbers in this assay, from the lowest: compound 3; then compound 4; then compounds 2 and 1 (each within the scatter of the next).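

Configuration at this one saturated ring carbon matters in this assay: drawing it R rather than S goes with a 3.0-fold lower number from compound 2 to compound 4 (0.48 log units; beyond the scatter), a modest step but the first in this series that can be read as a single change. That step can be placed on this stereocentre alone, with no group entering or leaving, because the structures offer no other difference: the fact that compounds 2 and 4 differ only in the configuration as drawn. The earlier compounds shown here could not show this, as no pair among them differed in only one place, so neither this position nor any change of configuration had yet been tested by a measured step.

The compounds shown leave open whether the other four stereo elements matter to a similar degree, and whether the same inversion would give a step of like size and direction with the butanoic acid chain of compound 1 in place of the cyclohexane carboxylic acid unit. They also leave open what the hydroxyl on this carbon contributes, and whether an amine, a methoxy group or a fluorine in its place would keep the number of compound 4 or move it.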